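Extending a side chain on a shared core

This account rests on a few compounds, and the source may have more. Where it says the series, first, only, none or still open, it means among the compounds named here.

Measured compounds:
compound 1, `O=C(Nc1ccc(Cl)cc1)NS(=O)(=O)c1cccs1`, 16%
compound 2, `CSc1ccc(S(=O)(=O)NC(=O)Nc2ccc(Cl)cc2)s1`, 29%
compound 3, `CCc1ccc(S(=O)(=O)NC(=O)Nc2ccc(Cl)cc2)s1`, 57%

In a functional assay on the whole organism (6C3HED cells, Mus musculus) for inhibition, at a dose of 150 mg/kg by the oral route (on this read-out lower numbers stand for less inhibition and higher numbers for more inhibition at the one dose given (going by the name of the read-out)), compound 1 stands lowest of the three, with compound 2 nearest and compound 3 furthest. Compound 4, `CCCc1ccc(S(=O)(=O)NC(=O)Nc2ccc(Cl)cc2)s1`, differs from compound 1 by propyl in place of hydrogen on an aromatic carbon. Among the compounds with values here, two measured steps bear on this: the large change a number 41 percentage points higher from compound 1 to compound 3 (beyond the scatter), and the smaller change a number 13 percentage points higher from compound 1 to compound 2 (beyond the scatter). Both steps put a group on the same carbon that compound 1 leaves bare, and both raise the number; the carbon chain in compound 3 raises it more than the sulfur-bearing group in compound 2. Propyl is a chain of the same kind as ethyl, only longer, so a rise beyond the scatter is expected, a number 44 percentage points higher from compound 1 to compound 4 (beyond the scatter). Compound 4 is therefore estimated at 60%, between 35% and 80%.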

Compound 4, a percentage reported as inhibition, in the whole organism at one dose (the size of the read-out at that dose, not a potency): 38%
Beside the measured number, compound 4's estimate is 22 percentage points above it; the measured number falls inside the stated range.
By their numbers in this assay, from the lowest: compound 1; then compounds 2 and 4 (each within the scatter of the next); then compound 3.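

Lengthening the carbon chain on the aromatic carbon next to the ring sulfur does not keep raising the number: propyl still gives a number 22 percentage points higher from compound 1 to compound 4 (beyond the scatter), yet the one added methyl on the ethyl chain gives a number 19 percentage points lower from compound 3 to compound 4 (beyond the scatter). Propyl and methylsulfanyl cannot be separated at this position, with a number 9 percentage points higher from compound 2 to compound 4 (within the scatter). Nothing available explains why ethyl stands above propyl here. The compounds shown leave open how methyl, a shorter chain than ethyl, would compare, and whether butyl would continue the fall. An amine at this position also remains untested in what is shown.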